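Working notes: from compound 2 to compound 3

The compounds below may be only part of what the source reports. "The series", "measured", "known", "first", "only" and "open" are said of these compounds alone.

Compound 1 (`CC(C)=CCOc1ccc2c(c1)OC(c1ccc(Br)cc1)CC2=O`): 8120 nM
Compound 2 (`CC(C)=CCOc1cc(O)c2c(c1)OC(c1ccccc1Cl)CC2=O`): 4270 nM

In a functional assay (on this read-out lower numbers stand for stronger inhibition and higher numbers for weaker inhibition), compound 2 at 4270 nM stands within the scatter of compound 1 at 8120 nM and holds no clear rank. Compound 3 (`CC(C)=CCOc1cc(O)c2c(c1)OC(c1ccc(Br)cc1)CC2=O`) carries 4-bromophenyl in place of 2-chlorophenyl on a saturated ring carbon. Within the data shown here, no measured pair isolates this change. Compound 1 also carries 4-bromophenyl, and at 8120 nM it is not separated from compound 2. In this assay the expected step is therefore estimated as a 1.1-fold higher number from compound 2 to compound 3 (0.05 log units; within the scatter). For compound 3 the estimate is 4800 nM with an expected range of 1800 nM to 12000 nM in this read-out.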

Compound 3, half-maximal inhibitory concentration: 2770 nM
Compound 3: middle estimate off by 1.7-fold (0.24 log units), on the high side; low and high end bracket the measured number.
By their numbers in this assay, from the lowest: compounds 3, 2 and 1 (each within the scatter of the next, the first and the last beyond it).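

In this assay, 4-bromophenyl in place of 2-chlorophenyl on the saturated ring carbon gives (a 1.5-fold lower number from compound 2 to compound 3 (0.19 log units; within the scatter)), so the two aryl groups cannot be told apart at this position. Among these compounds, with 4-bromophenyl held fixed, hydroxy in place of hydrogen on an aromatic carbon gives (a 2.9-fold lower number from compound 1 to compound 3 (0.47 log units; beyond the scatter)), the only step here beyond the scatter. Nothing at hand speaks to a cause for either step. Open, on these data alone, is how an amine or a carboxylic acid in place of the aryl group on that saturated ring carbon would read, and whether the hydroxy step holds with 2-chlorophenyl.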